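A Sulfur-Bearing Side Chain Replaces Isopropyl on a Shared Core

The compounds below may be only part of what the source reports. "The series", "measured", "known", "first", "only" and "open" are said of these compounds alone.

Compound 3 `CC(C)C[C@H](NC(=O)CN(c1ncnc2c1ncn2C1CCCCO1)C1CC1)C(=O)OCc1ccccc1` gives 28.2% in a functional assay on the whole organism (Tail, strain ICR) with Mus musculus as the target, in the tail flick test, with a stated time of 90 min, at a dose of 25 umol/kg by the oral route (on this read-out higher numbers stand for a stronger effect at the one dose given and lower numbers for a weaker effect), the lowest of the three numbers, though within the scatter of both neighbours. Compound 1 `C[C@H](NC(=O)CN(c1ncnc2c1ncn2C1CCCCO1)C1CC1)C(=O)OCc1ccccc1` gives 32.1% and compound 2 `CC(C)(C)OC(=O)NCCCC[C@H](NC(=O)CN(c1ncnc2c1ncn2C1CCCCO1)C1CC1)C(=O)OCc1ccccc1` gives 32.9%. The steps of a number 3.9 percentage points lower from compound 1 to compound 3 (within the scatter) and a number 4.7 percentage points lower from compound 2 to compound 3 (within the scatter) lie within the scatter, as does a number 0.8 percentage points higher from compound 1 to compound 2 (within the scatter). Compound 4 `CSCC[C@H](NC(=O)CN(c1ncnc2c1ncn2C1CCCCO1)C1CC1)C(=O)OCc1ccccc1` differs from compound 3 by (methylsulfanyl)methyl in place of isopropyl on a saturated chain carbon, two bonds along the chain from an amide-type nitrogen and a carbonyl carbon. Each measured exchange at that same chain carbon, from hydrogen to isopropyl or to 3-((tert-butoxycarbonyl)amino)propyl, left this assay unchanged beyond the scatter, so the expected step for compound 4 is a number 1.8 percentage points higher from compound 3 to compound 4 (within the scatter), none beyond the scatter. Compound 4 is therefore estimated at 30% in this assay, with a range from 20% to 40%.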

Compound 4, a percentage reported as activity, at one dose (the size of the read-out at that dose, not a potency): 42.7%
For compound 4 the middle estimate is 12.7 percentage points below the measured one; measured number above the stated range.
By their numbers in this assay, from the lowest: compounds 3, 1, 2 and 4 (each within the scatter of the next, the first and the last beyond it).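

In this assay this chain carbon now shows a change beyond the scatter, with a number 14.5 percentage points higher from compound 3 to compound 4 (beyond the scatter) and a number 10.6 percentage points higher from compound 1 to compound 4 (beyond the scatter) as well, where the exchanges among hydrogen, isopropyl and 3-((tert-butoxycarbonyl)amino)propyl had shown none. The result is not separated from the carbamate-bearing chain, with a number 9.8 percentage points higher from compound 2 to compound 4 (within the scatter) for that pair, so the rise holds against only two of the three earlier side chains. Nothing available here explains the rise.

Whether the sulfur matters or only the unbranched chain stays open, as the compounds shown include no plain butyl chain at this carbon. On these data alone, a free amine at the end of the chain is equally open.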